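A few compounds are considered here, and "the series" means these few. Any claim that something is new, unique, unknown or untested is made for them only; others in the source may bear on it.

Compound 2 `O=c1ccoc2cc(OCc3cn(Cc4ccccc4Cl)nn3)ccc12` is the starting point of this comparison. In an ADME assay on L02 cells (Homo sapiens) for cytotoxicity, read by MTT assay, with a stated time of 48 h (a lower number here means a stronger inhibitor, a higher number a weaker inhibitor), compound 2 gives > 300000 nM, which is a limit of the assay rather than a number. Its two neighbours sit the same way. Compound 1 `Cc1ccccc1Cn1cc(COc2ccc3c(=O)ccoc3c2)nn1` gives > 300000 nM in this assay, a limit and not a number. Compound 3 `O=c1ccoc2cc(OCc3cn(Cc4ccc(F)cc4)nn3)ccc12` gives > 300000 nM in this assay, again a limit. Because of the limit of > 300000 nM in this assay, at which 3 of the 3 values shown sit, none of the steps among these three can be read: the step that the two limits leave unreadable from compound 1 to compound 2, the step that the two limits leave unreadable from compound 1 to compound 3 and the step that the two limits leave unreadable from compound 2 to compound 3 all fall between two limits.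

Compound 4 `N#Cc1cccc(Cn2cc(COc3ccc4c(=O)ccoc4c3)nn2)c1` differs from compound 2 by 3-cyanophenyl in place of 2-chlorophenyl on a saturated chain carbon bound to an aromatic nitrogen. The measured steps that bear on this change, all of which swap one substituted phenyl for another on the same saturated chain carbon, are the three steps just named, and none of them gives a readable size. For the measured compounds named here, the data therefore provide no measured step whose magnitude can be carried over; what they do show is that every compound measured so far sits at the limit of this assay.

On that basis compound 4 is expected to behave like compound 2, so the step of a number no higher from compound 2 to compound 4 (the limit leaves the size open) is estimated to be none beyond the scatter. Compound 4 is estimated at 300000 nM in this assay, with a range from 100000 nM to 1000000 nM.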

Compound 4, half-maximal inhibitory concentration: > 300000 nM
Compound 4: no number, only a limit; the forecaster's own chance of this, stated with the estimate: 85%; the middle value lies on the limit itself.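

In this assay compound 4 gives > 300000 nM, a limit and not a number. The steps to compound 4 from compound 1, compound 2 and compound 3 therefore cannot be read, because all of them fall under the same condition: the limit of > 300000 nM in this assay, at which 4 of the 4 values shown sit. The compounds shown leave open whether swapping one substituted phenyl for another changes the value at all.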